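The source may report more compounds than this note shows. Statements on the series, on what has been measured and on what is new or still open speak of the compounds shown alone.

Measured so far in a functional assay on HEK293 cells for positive allosteric modulation of metabotropic glutamate receptor 5 (Rattus norvegicus), read by fluorescence and calcium flux; a lower number here means a smaller maximal response, a higher number a larger maximal response:

- compound 1 `C[C@@H](NC(=O)c1ccc(C#Cc2cc(F)cc(F)c2)cn1)C(C)(C)O` gives 61.6%
- compound 2 `Cc1ccc(C#Cc2ccc(C(=O)N[C@H](C)C(C)(C)O)nc2)cc1` gives 63.1%
- compound 3 `C[C@@H](NC(=O)c1ccc(C#Cc2cc(F)ccn2)cn1)C(C)(C)O` gives 66.2%

Compound 3 carries the highest of the three numbers, but this says little: the step of a number 3.1 percentage points higher from compound 2 to compound 3 (within the scatter) and the step of a number 4.6 percentage points higher from compound 1 to compound 3 (within the scatter) both lie within the scatter, as does a number 1.5 percentage points higher from compound 1 to compound 2 (within the scatter). All three compounds share one core and differ only in the group on the triple-bonded carbon, and none of those exchanges moved the maximal response beyond the scatter.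

Compound 4 `C[C@@H](NC(=O)c1ccc(C#Cc2ncccc2F)cn1)C(C)(C)O` is the next member. Its difference from compound 3: 3-fluoropyridin-2-yl in place of 4-fluoropyridin-2-yl on a triple-bonded carbon

The three measured steps all concern the same place and were all within the scatter; the change to compound 4 is the smallest of the lot, the same atoms joined differently. No step beyond the scatter is therefore expected, a number 2.2 percentage points lower from compound 3 to compound 4 (within the scatter). For compound 4 the expected value in this assay is 64%, estimated to fall between 52% and 76%.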

Compound 4, largest response reached (reported as efficacy), in percent of the reference or control that the assay uses: 60.6%
For compound 4 the middle estimate is 3.4 percentage points above the measured one; low and high end bracket the measured number.
By their numbers in this assay, from the lowest: compounds 4, 1, 2 and 3 (each within the scatter of the next).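

In this assay, even an exchange of the same atoms joined differently, 3-fluoropyridin-2-yl in place of 4-fluoropyridin-2-yl on the triple-bonded carbon, gives a number 5.6 percentage points lower from compound 3 to compound 4 (within the scatter) and so does not separate the two pyridines. The exchanges for the two phenyl groups, a number 2.5 percentage points lower from compound 2 to compound 4 (within the scatter) and a number 1 percentage points lower from compound 1 to compound 4 (within the scatter) likewise, leave all four groups at this position indistinguishable in maximal response. No accompanying measurement offers an account of this flat picture.

Open, as far as these compounds go, is whether a group of another kind on the triple-bonded carbon, such as cyclohexyl, pyrimidin-2-yl or aminomethyl, would stay within the same scatter. From the compounds shown here alone, the shared core is constant across all four compounds, and the effect of an exchange there, for example a carboxylic acid in place of its hydroxyl, remains open.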